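Dibromo-hydroxyphenyl hydrazone: expected potency after fluorine loss

This account rests on a few compounds, and the source may have more. Where it says the series, first, only, none or still open, it means among the compounds named here.

For the measured compounds named here, compound 1 `O=C(N/N=C/c1ccc(F)cc1)Nc1ccc(Oc2ccnc3[nH]ccc23)c(F)c1` is the one member of this series with a number in a functional assay on MCF7 cells (Homo sapiens) for antiproliferative activity, read by MTT assay, with a stated time of 72 h (on this read-out higher numbers stand for weaker inhibition and lower numbers for stronger inhibition), where compound 1 gives 800 nM. Going by the values given here, its companion compound 2 `O=C(N/N=C/c1ccc(O)cc1)Nc1ccc(Oc2ccnc3[nH]ccc23)c(F)c1` was reported in this assay as "not active" (no number reported), with no number given, so no step between measured compounds can be drawn. The unmeasured compound 3 `O=C(N/N=C/c1cc(Br)c(O)c(Br)c1)Nc1ccc(Oc2ccnc3[nH]ccc23)c(F)c1` differs from compound 1 in one place: 3,5-dibromo-4-hydroxyphenyl in place of 4-fluorophenyl on a carbon with a double bond to nitrogen. Among the compounds with values here, with no measured step to lean on, and with compound 2 showing that a change at the same position can abolish activity, a modest loss beyond the scatter is expected, a 3.1-fold higher number from compound 1 to compound 3 (0.49 log units; beyond the scatter) in this assay. Compound 3 is therefore estimated to give 2500 nM in this assay, with a range from 600 nM to 12000 nM, and a real chance that only a limit is reported.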

Compound 3, half-maximal inhibitory concentration: "not active" (no number reported)
Compound 3: no number reported; no gap can be computed for the estimate.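

In this assay, for the compounds shown here, compound 3, like compound 2, was reported as "not active" without a number, so no step from compound 1 to either can be read. Nothing shown bears on this result. The compounds shown leave open where compound 2 and compound 3 stand numerically against compound 1.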